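Diacid Amide Side Chains and Antiproliferative Potency

The source may report more compounds than this note shows. Statements on the series, on what has been measured and on what is new or still open speak of the compounds shown alone.

Compound 1: `CCn1c(C(=O)NCCNC(=O)OC(C)(C)C)ccc1C(CC)(CC)c1ccc(OCS(=O)(=O)c2ccccc2)c(C)c1` — > 50000 nM
Compound 2: `CCn1c(C(=O)N[C@H](CO)CCO)ccc1C(CC)(CC)c1ccc(OCS(=O)(=O)c2ccccc2)c(C)c1` — 15900 nM
Compound 3: `CCn1c(C(=O)N[C@@H](CC(=O)O)C(=O)O)ccc1C(CC)(CC)c1ccc(OCS(=O)(=O)c2ccccc2)c(C)c1` — > 50000 nM

Three compounds share one core and differ only in the group on the amide-type nitrogen. In a functional assay on BXPC-3 cells (Homo sapiens) for antiproliferative activity, read by MTT assay, with a stated time of 24 h (on this read-out lower numbers stand for stronger inhibition and higher numbers for weaker inhibition), compound 1 gives > 50000 nM, which is a limit of the assay rather than a number. Compound 2 gives 15900 nM. Compound 3 gives > 50000 nM, again a limit. The step of an at least 3.1-fold lower number from compound 1 to compound 2 (0.49 log units; beyond the scatter) is readable, whereas a step that the two limits leave unreadable from compound 1 to compound 3. Compound 4, `CCn1c(C(=O)N[C@@H](CCC(=O)O)C(=O)O)ccc1C(CC)(CC)c1ccc(OCS(=O)(=O)c2ccccc2)c(C)c1`, is not yet measured; it carries 1,3-dicarboxypropyl in place of 2-((tert-butoxycarbonyl)amino)ethyl on an amide-type nitrogen. The closest measured step is an at least 3.1-fold higher number from compound 2 to compound 3 (0.49 log units; beyond the scatter), and because the limit of > 50000 nM in this assay, at which 2 of the 3 values shown sit, compound 4 is expected to sit at that limit too. Compound 4 is therefore estimated at 50000 nM, within 20000 nM to 100000 nM. For compound 4 the expected step is a number no higher from compound 1 to compound 4 (the limit leaves the size open).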

Compound 4, half-maximal inhibitory concentration: > 50000 nM
Compound 4 gave a limit, no number; the forecaster's own chance of this, stated with the estimate: 75%; the middle value sits exactly at the limit.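

Replacing carboxy with carboxymethyl on the chain does not restore a readable potency: compound 4, like compound 3, sits at a limit, so neither diacid side chain can be ranked against the other. Among the compounds shown here, the 3-hydroxy-1-(hydroxymethyl)propyl group of compound 2 still gives the only real number here, with an at least 3.1-fold higher number from compound 2 to compound 4 (0.49 log units; beyond the scatter). The steps to compound 4 from compound 1 and compound 3 cannot be read, and limits now fill most of the set: the limit of > 50000 nM in this assay, at which 3 of the 4 values shown sit.

As far as these compounds go, whether a free amine or a single hydroxyethyl chain on the amide nitrogen would give a number stays open.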